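This account rests on a few compounds, and the source may have more. Where it says the series, first, only, none or still open, it means among the compounds named here.

Working notes on the series. Compound 2 `O=C(OCCc1ccc(Cl)c(Cl)c1)N(c1ccccc1)C1CN2CCC1CC2` gives 80 nM in an assay on CHO cells for displacement of a labelled ligand from muscarinic acetylcholine receptor M5 (Homo sapiens), read by scintillation counting, with a stated time of 2 h (a lower number here means a stronger inhibitor, a higher number a weaker inhibitor), the second highest of the three numbers in hand. Compound 1 `COc1ccc(COC(=O)N(c2ccccc2)C2CN3CCC2CC3)cc1F` gives 40 nM, and the step of a 2.0-fold higher number from compound 1 to compound 2 (0.30 log units; within the scatter) is within the scatter. Compound 3 `COc1ccc(COC(=O)N(c2ccccc2)C2CN3CCC2CC3)cc1` gives 470 nM, and the step of a 5.9-fold higher number from compound 2 to compound 3 (0.77 log units; beyond the scatter) is beyond it, as is the step of a 12-fold higher number from compound 1 to compound 3 (1.07 log units; beyond the scatter).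

Compound 4 `COc1ccc(CCCOC(=O)N(c2ccccc2)C2CN3CCC2CC3)cc1` is not yet measured in this assay. Its change from compound 2 is 4-methoxybenzyl in place of 3,4-dichlorophenyl on a saturated chain carbon, two bonds along the chain from an oxygen next to a carbonyl group. Within the data shown here, the one step that bears on it is the swap at the chain carbon from compound 2 to compound 3, which gave a 5.9-fold higher number from compound 2 to compound 3 (0.77 log units; beyond the scatter); there the 3,4-dichloro group also left and a 4-methoxy aryl group entered. Among the measured compounds shown here, compound 4 carries the 4-methoxy aryl group on a longer chain than compound 3, and no measured pair shows what such a chain lengthening does. The expected step is therefore a 5.0-fold higher number from compound 2 to compound 4 (0.70 log units; beyond the scatter), weaker, in the direction of compound 3. The estimate for compound 4 is 400 nM, with a range from 130 nM to 1300 nM.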

Compound 4, inhibition constant: 640 nM
The estimate for compound 4 lay 1.6-fold (0.20 log units) below the measured number; measured number inside the range.
By their numbers in this assay, from the lowest: compounds 1 and 2 (each within the scatter of the next); then compounds 3 and 4 (each within the scatter of the next).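

At this chain carbon, 4-methoxybenzyl in place of 3,4-dichlorophenyl gives an 8.0-fold higher number from compound 2 to compound 4 (0.90 log units; beyond the scatter), so the loss seen with the 4-methoxy aryl group on the shorter chain also appears on the longer one. Compound 3 at 470 nM and compound 4 at 640 nM lie within the scatter of each other, the first sign in the series that this chain lengthening leaves the number in this assay essentially in place for the 4-methoxy aryl group. The data hold nothing that explains the step from 3,4-dichlorophenyl to 4-methoxybenzyl.

The compounds shown leave open whether a 3-fluoro-4-methoxybenzyl group would bring the lower numbers back on the longer chain. On these data alone, how a pyridine ring, an amine or a carboxylic acid would fare at this place also remains open.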